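The compounds below may be only part of what the source reports. "The series", "measured", "known", "first", "only" and "open" are said of these compounds alone.

Measured in an assay on isolated protein for agonist activity at Bile acid receptor (Homo sapiens), read by TR-FRET; a higher number here means that more compound is needed for the effect, a lower number that less compound is needed:

compound 1 `CCC(CC)n1c(-c2ccc(OCc3c(-c4c(Cl)cccc4Cl)noc3C(C)C)cc2)nc2ccc(C(=O)O)cc21` gives 26.5 nM
compound 2 `CC(C)c1onc(-c2c(Cl)cccc2Cl)c1COc1ccc(-c2nc3ccc(C(=O)O)cc3n2-c2ccc(F)cc2)cc1` gives 15.1 nM
compound 3 `CC(C)c1onc(-c2c(Cl)cccc2Cl)c1COc1ccc(-c2nc3ccc(C(=O)O)cc3n2CC2CC2)cc1` gives 29.1 nM

Compound 1 has the second highest number of the three; compound 3 lies nearest with a 1.1-fold higher number from compound 1 to compound 3 (0.04 log units; within the scatter), and compound 2 furthest with a 1.8-fold lower number from compound 1 to compound 2 (0.24 log units; within the scatter). Compound 2 and compound 3 are also close, a 1.9-fold higher number from compound 2 to compound 3 (0.28 log units; within the scatter). All three numbers sit within the scatter of one another, so the group on the aromatic nitrogen has so far made no resolvable difference.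

Compound 4 `CC(C)c1onc(-c2c(Cl)cccc2Cl)c1COc1ccc(-c2nc3ccc(C(=O)O)cc3n2C2CCCCCC2)cc1` is not yet measured in this assay. It differs from compound 1 as follows: cycloheptyl in place of pentan-3-yl on an aromatic nitrogen. For the measured compounds named here, the steps that bear on this are the three exchanges at the same aromatic nitrogen, pentan-3-yl to 4-fluorophenyl, pentan-3-yl to cyclopropylmethyl and 4-fluorophenyl to cyclopropylmethyl, each within the scatter. A cycloheptyl at this position has no direct precedent here, but the three prior exchanges give no reason to expect a step beyond the scatter in this assay, in either direction.

Compound 4 is therefore expected at about 30 nM, with a range of 12 nM to 75 nM, which means an expected step of a 1.1-fold higher number from compound 1 to compound 4 (0.05 log units; within the scatter) from compound 1.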

Compound 4, half-maximal effective concentration: 113 nM
Beside the measured number, compound 4's estimate is 3.8-fold (0.58 log units) below it; the whole stated range lies below it.
By their numbers in this assay, from the lowest: compounds 2, 1 and 3 (each within the scatter of the next); then compound 4.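

In this assay the aromatic nitrogen no longer looks indifferent to the group it carries: the steps of a 4.3-fold higher number from compound 1 to compound 4 (0.63 log units; beyond the scatter) and a 3.9-fold higher number from compound 3 to compound 4 (0.59 log units; beyond the scatter) and a 7.5-fold higher number from compound 2 to compound 4 (0.87 log units; beyond the scatter) all lie beyond the scatter, whereas pentan-3-yl, cyclopropylmethyl and 4-fluorophenyl remain within the scatter of one another. For the compounds shown here, the exchange of pentan-3-yl, with 5 heavy atoms and no ring, for cycloheptyl, with 7 heavy atoms in a seven-membered non-aromatic ring of carbon only, is therefore the first change at this position to give a resolvable step, so not every carbon-only group here is interchangeable. No measurement at hand accounts for this step.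

The compounds shown leave open whether the higher number goes with the seven-membered ring itself or with the larger group in general, a question that cyclopentyl and cyclohexyl at the same nitrogen would help to settle. They also leave open whether a ring of the same size holding an oxygen or an amine nitrogen would follow cycloheptyl or stay with the other three groups.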